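The source may hold more compounds than are shown below. What is called first, only, known or untested is meant among the compounds shown, and "the series" means these compounds.

Measured in an ADME assay on MT4 cells (Homo sapiens) for cytotoxicity, read by MTT assay, with a stated time of 5 days; a higher number here means that more compound is tolerated, a lower number that less compound is tolerated:

- compound 1 `COc1cc2cc(C#N)ccc2c(OC)c1Oc1cc(NC(C)C)nc(Nc2ccc(C#N)cc2)n1`: > 125000 nM
- compound 2 `CCC(CC)Nc1cc(Oc2c(OC)cc3cc(C#N)ccc3c2OC)nc(Nc2ccc(C#N)cc2)n1`: > 125000 nM
- compound 3 `CCCCCC(C)Nc1cc(Oc2c(OC)cc3cc(C#N)ccc3c2OC)nc(Nc2ccc(C#N)cc2)n1`: > 125000 nM

Compound 1 gives > 125000 nM, which is a limit of the assay and not a number. The other two compounds offer no firmer reference point, as the evidence shows: the limit of > 125000 nM in this assay, at which 3 of the 3 values shown sit.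

Compound 4 `CCCC(CCC)Nc1cc(Oc2c(OC)cc3cc(C#N)ccc3c2OC)nc(Nc2ccc(C#N)cc2)n1` has not yet been measured. It keeps the core of compound 1 and changes one group: 1-propylbutyl in place of isopropyl on a nitrogen on an aromatic ring. Put simply, 1-propylbutyl takes the place of isopropyl on a nitrogen on an aromatic ring.

Three measured steps change the group on that same nitrogen. Among the compounds with values here, the first is a step that the two limits leave unreadable from compound 1 to compound 2. The second is a step that the two limits leave unreadable from compound 1 to compound 3. The third is a step that the two limits leave unreadable from compound 2 to compound 3. None of them has a readable size, so they give no direction, but neither of the two other groups tried on this nitrogen brought a value below the limit. In this assay, no step beyond the usual scatter is therefore expected, and the most likely result is another limit rather than a number. The expected change is a number no higher from compound 1 to compound 4 (the limit leaves the size open). For compound 4 the estimated value is 125000 nM, with an expected range from 50000 nM to 200000 nM.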

Compound 4, half-maximal cytotoxic concentration: > 125000 nM
Compound 4 gave a limit, no number (the forecaster's own chance of this, stated with the estimate: 85%); the middle value sits exactly at the limit.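

In this assay compound 4 gives > 125000 nM, which is a limit and not a number. No step from compound 1, compound 2 or compound 3 to compound 4 can be read, and the evidence is this: the limit of > 125000 nM in this assay, at which 4 of the 4 values shown sit.

Left open is the concentration at which any of these compounds harms the cells, and whether the groups on that nitrogen differ at all in this assay.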